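Bromo for chloro in a series without readable potency

The source may hold more compounds than are shown below. What is called first, only, known or untested is meant among the compounds shown, and "the series" means these compounds.

Compound 1 `O=C1Nc2ccc(Cl)cc2/C1=C/c1cccc(OCc2cn(Cc3ccccc3)nn2)c1` was tested in a functional assay on A549 cells (Homo sapiens) for inhibition, read by MTT assay, with a stated time of 48 h; on this read-out higher numbers stand for weaker inhibition and lower numbers for stronger inhibition. In this assay compound 1 gives > 50000 nM, which is a limit of the assay and not a number. Compound 3 `O=C1Nc2ccc(Br)cc2/C1=C/c1cccc(OCc2cn(Cc3ccccc3)nn2)c1` carries bromo in place of chloro on an aromatic carbon. In this assay compound 3 gives > 50000 nM, again a limit. The step that the two limits leave unreadable from compound 1 to compound 3 stays unreadable owing to the limit of > 50000 nM in this assay, at which 3 of the 3 values shown sit. Compound 2 `O=C1Nc2cc(Cl)ccc2/C1=C\c1cccc(OCc2cn(Cc3ccccc3)nn2)c1` has the same atoms as compound 1 joined differently; the difference between the two cores is not broken down here. In this assay compound 2 gives > 50000 nM, a limit as well. Compound 4 `O=C1Nc2cc(Br)ccc2/C1=C\c1cccc(OCc2cn(Cc3ccccc3)nn2)c1` has not yet been measured; it carries bromo in place of chloro on an aromatic carbon, the same change as that from compound 1 to compound 3, at the same place. The step that the limit leaves unreadable from compound 2 to compound 4 is expected to be small, resting on compound 1 and compound 3 both sitting at the limit, as a step that the two limits leave unreadable from compound 1 to compound 3 shows. Compound 4 is therefore expected to give 80000 nM in this assay, within 30000 nM to 300000 nM, and most likely only as a limit.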

Compound 4, half-maximal inhibitory concentration: 9600 nM
Compound 4: the middle estimate sits 8.3-fold (0.92 log units) above what was measured; the measured number lies below the stated range.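

On the core of compound 2, bromo in place of chloro on an aromatic carbon gives, in this assay, an at least 5.2-fold lower number from compound 2 to compound 4 (0.71 log units; beyond the scatter), so the change has a readable effect on this core. Compound 2 gives > 50000 nM, a limit of the assay and not a number, so the step has a lower bound but no full size. The step from compound 1 to compound 3 cannot be read, which leaves no second size to set against the first and shows neither that the change carries from one core to the other nor that it fails to: the limit of > 50000 nM in this assay, at which 3 of the 4 values shown sit.

Open, from the compounds shown here alone, is whether the step on the core of compound 4 is specific to bromo, or whether iodo or methoxy in the same place would also bring a readable number. Also open, going by these compounds, is whether compound 4 would keep a readable number in this assay with an amine or a carboxylic acid added elsewhere on the molecule.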